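Ortho fluoro on the methoxyphenyl amide of compound 1

The source may hold more compounds than are shown below. What is called first, only, known or untested is meant among the compounds shown, and "the series" means these compounds.

Compound 1 `COc1ccc(C(=O)Nc2cccc(-c3oc4cc(-c5ccc(F)cc5)ccc4c(=O)c3O)c2)cc1` is the reference for this step. In a functional assay on HeLa cells (Homo sapiens) for antiproliferative activity, read by CCK-8 assay, with a stated time of 72 h (on this read-out lower numbers stand for stronger inhibition and higher numbers for weaker inhibition), compound 1 gives 4820 nM. Among the measured compounds shown here, only one other compound has been measured: compound 2 `O=C(Nc1cccc(-c2oc3cc(-c4ccc(F)cc4)ccc3c(=O)c2O)c1)c1ccc(Cl)cc1`, which in this assay gives 3670 nM. On the numbers shown compound 1 therefore stands alongside compound 2, with a 1.3-fold lower number from compound 1 to compound 2 (0.12 log units; within the scatter), so the two are not separated beyond the scatter.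

Compound 3 `COc1ccc(C(=O)Nc2cccc(-c3oc4cc(-c5ccc(F)cc5)ccc4c(=O)c3O)c2)c(F)c1` differs from compound 1 by fluoro in place of hydrogen on an aromatic carbon. For the measured compounds named here, no measured step adds a fluoro in this way; the only step available, from compound 1 to compound 2, changes a different substituent on the same ring and is a 1.3-fold lower number from compound 1 to compound 2 (0.12 log units; within the scatter), which gives no sign that small edits to this ring move this assay beyond the scatter. For compound 3 a step of a 1.1-fold lower number from compound 1 to compound 3 (0.03 log units; within the scatter) is therefore expected, meaning no change beyond the scatter. The estimate for compound 3 in this assay is 4500 nM, with an expected range from 2000 nM to 10000 nM.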

Compound 3, half-maximal inhibitory concentration: 16100 nM
Estimate against measurement, compound 3: 3.6-fold (0.55 log units) below; the measured number lies above the stated range.
By their numbers in this assay, from the lowest: compounds 2 and 1 (each within the scatter of the next); then compound 3.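

In this assay, among the compounds shown here, fluoro in place of hydrogen on an aromatic carbon, ortho to a large group and meta to the methoxy group, gives a 3.3-fold higher number from compound 1 to compound 3 (0.52 log units; beyond the scatter), the first step beyond the scatter, and it goes towards weaker inhibition. The other new step, a 4.4-fold higher number from compound 2 to compound 3 (0.64 log units; beyond the scatter), is also beyond the scatter, so a single added fluorine at this place separates compound 3 from two compounds that are themselves within the scatter of each other. No data here bear on why this added fluoro has this effect.

From the compounds shown here alone, it remains open whether this step is specific to fluoro or would also appear with a chloro, methyl or amino group at the same place. Going by these compounds, it also remains open whether the same fluoro on the 4-chlorophenyl amide of compound 2 would give a step of similar size.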